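A few compounds are considered here, and "the series" means these few. Any claim that something is new, unique, unknown or untested is made for them only; others in the source may bear on it.

Working notes on the series. The shared core of compound 1 `CC(C)CN1CCc2nc(C#Cc3ccccc3)sc2C1` carries an isobutyl group on the ring nitrogen; in an assay on HEK293 cells for positive allosteric modulation of metabotropic glutamate receptor 5 (Homo sapiens), read by FLIPR, with a stated time of 1 h (on this read-out lower numbers stand for an effect already at smaller amounts and higher numbers for an effect only at larger amounts of compound), compound 1 gives only a limit, > 10000 nM, and no number. Compound 2 `CC1CCC(C(=O)N2CCc3nc(C#Cc4ccccc4)sc3C2)CC1` carries a 4-methylcyclohexyl amide on the same nitrogen instead; in this assay compound 2 gives 190 nM, the only finite number shown in the set. The other value, that of compound 1, is a limit (the limit of > 10000 nM in this assay, at which 1 of the 2 values shown sits). Compound 3 `O=C(C1CCOCC1)N1CCc2nc(C#Cc3ccccc3)sc2C1` is the next member: oxan-4-yl in place of 4-methylcyclohexyl on a carbonyl carbon. Within the data shown here, no measured pair in the set isolates this kind of exchange, so the size of the step is not known from the data; the expectation is a moderate loss, a 3.7-fold higher number from compound 2 to compound 3 (0.57 log units; beyond the scatter), beyond the usual scatter. Compound 3 is accordingly estimated at 700 nM in this assay, with a likely range from 200 nM to 3000 nM.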

Compound 3, half-maximal effective concentration: 290 nM
Compound 3: middle estimate off by 2.4-fold (0.38 log units), on the high side; the range from low to high includes it.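

In this assay, oxan-4-yl in place of 4-methylcyclohexyl on a carbonyl carbon gives a 1.5-fold higher number from compound 2 to compound 3 (0.18 log units; within the scatter), so in these two compounds a six-membered ring with a hetero atom and one of carbon only cannot be told apart. A second amide on the ring nitrogen now reads as a finite value, and the exchange of isobutyl for (oxan-4-yl)carbonyl gives an at least 34-fold lower number from compound 1 to compound 3 (1.53 log units; beyond the scatter). The value of compound 1 is a limit and not a number: the limit of > 10000 nM in this assay, at which 1 of the 3 values shown sits.

On these data alone, that exchange alters both the link to the ring nitrogen and the group on it, so the share of the carbonyl itself stays open. As far as these compounds go, how a piperidin-4-yl ring with its amine, a carboxylic acid or a longer open chain on the same carbonyl carbon would read also stays open.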